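Trading a phenoxy for a methoxy on the benzyl amide

The source may hold more compounds than are shown below. What is called first, only, known or untested is meant among the compounds shown, and "the series" means these compounds.

Measured so far:
- Compound 1, `N[C@H]1CC[C@H](Nc2c(C(=O)NCc3ccc(Oc4ccccc4)cc3)nc(Br)c3cccnc23)CC1`: 4000 nM
- Compound 2, `NCCCNc1c(C(=O)NCc2ccc(F)cc2)ncc2cccnc12`: 16000 nM
- Compound 3, `NCCNc1c(C(=O)NCc2ccc(F)cc2)nc(Br)c2cccnc12`: 12000 nM

All three compounds were tested in a functional assay on MDA-MB-435 cells (Homo sapiens) for cytotoxicity, read by MTT assay, with a stated time of 72 h; on this read-out higher numbers stand for weaker inhibition and lower numbers for stronger inhibition. Compound 1 gives the lowest number of the three, and its gaps to compound 3 and to compound 2 both lie beyond the usual scatter, so among these three compound 1 is the strongest inhibitor. Compound 2 and compound 3 carry shorter amine chains and a fluorine on the benzyl ring, and their numbers sit close to each other.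

The next compound, compound 4, `COc1ccc(CNC(=O)c2nc(Br)c3cccnc3c2N[C@H]2CC[C@H](N)CC2)cc1`, keeps the whole core and the cyclohexane diamine of compound 1 and changes only the group on the benzyl ring: methyl in place of phenyl on an oxygen on an aromatic ring. Read one bond further out, the change is phenoxy to methoxy.

Among the measured compounds shown here, no measured pair shows what this particular swap does, so the expectation rests on compound 1 alone. The group that leaves is much larger than the one that enters, and the measured compounds with small benzyl substituents, compound 2 and compound 3, sit at weaker numbers, though they also differ elsewhere. A moderate step toward weaker inhibition is expected, a 2.0-fold higher number from compound 1 to compound 4 (0.30 log units; within the scatter), somewhat beyond the scatter but not large. Compound 4 is therefore estimated at 8000 nM, within a range of 3000 nM to 25000 nM.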

Compound 4, half-maximal inhibitory concentration: 5000 nM
Compound 4: the middle estimate sits 1.6-fold (0.20 log units) above what was measured; the measured number falls inside the stated range.
By their numbers in this assay, from the lowest: compounds 1 and 4 (each within the scatter of the next); then compounds 3 and 2 (each within the scatter of the next).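

In this assay, putting methyl in place of phenyl on an oxygen on an aromatic ring gives a 1.3-fold higher number from compound 1 to compound 4 (0.10 log units; within the scatter) and so leaves no difference that can be told from the scatter of repeated measurements. Among the compounds shown here, this is the first pair that differs in one place only. Compound 4 carries methyl where compound 1 carries the outer six-membered aromatic ring, and this read-out shows no measurable change. No independent measurement is at hand to explain why compound 1 and compound 4 read alike.

On these data alone, what stays open is whether anything on this oxygen matters at all, since a hydroxyl, a longer chain such as butoxy, or an amine in place of the oxygen could each test how far this tolerance reaches. As far as these compounds go, the comparison also holds only for the core and cyclohexane diamine that compound 1 and compound 4 share, so it remains open whether the same swap would read alike with the shorter amine chains of compound 2 and compound 3.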